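The source may hold more compounds than are shown below. What is called first, only, known or untested is meant among the compounds shown, and "the series" means these compounds.

In a functional assay on MCF7 cells (Homo sapiens) for antiproliferative activity, read by MTT assay, with a stated time of 24 h (a higher number here means a weaker inhibitor, a lower number a stronger inhibitor), compound 1 `CCn1c(C(=O)N[C@H](C)CO)ccc1C(CC)(CC)c1ccc(OCS(=O)(=O)c2ccccc2)c(C)c1` gives 10600 nM, compound 2 `CCn1c(C(=O)NC(C)(C)CO)ccc1C(CC)(CC)c1ccc(OCS(=O)(=O)c2ccccc2)c(C)c1` gives 20700 nM and compound 3 `CCn1c(C(=O)N[C@@H](CO)CCCO)ccc1C(CC)(CC)c1ccc(OCS(=O)(=O)c2ccccc2)c(C)c1` gives 29600 nM. Two steps place compound 3: a 1.4-fold higher number from compound 2 to compound 3 (0.16 log units; within the scatter) stays within the scatter, whereas a 2.8-fold higher number from compound 1 to compound 3 (0.45 log units; beyond the scatter) is a modest one beyond it. Compound 4 `CCn1c(C(=O)N[C@@H](C(=O)O)C(C)C)ccc1C(CC)(CC)c1ccc(OCS(=O)(=O)c2ccccc2)c(C)c1` carries 1-carboxy-2-methylpropyl on the amide-type nitrogen, (a group of 7 heavy atoms (5 carbon, 2 oxygen; no ring) in place of a group of 7 heavy atoms (5 carbon, 2 oxygen; no ring), on an amide-type nitrogen). Going by the values given here, no measured compound bears a carboxy group, so the measured steps offer only indirect guidance. a 2.0-fold higher number from compound 1 to compound 2 (0.29 log units; within the scatter) also stays within the scatter, which leaves the modest step as the largest seen on this nitrogen. No change beyond the scatter is therefore expected in this assay, and the estimated step is a 1.2-fold lower number from compound 3 to compound 4 (0.09 log units; within the scatter). Compound 4 is expected at 24000 nM, within an estimated range of 9000 nM to 60000 nM.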

Compound 4, half-maximal inhibitory concentration: 44700 nM
The estimate for compound 4 lay 1.9-fold (0.27 log units) below the measured number; low and high end bracket the measured number.
By their numbers in this assay, from the lowest: compounds 1, 2, 3 and 4 (each within the scatter of the next, the first and the last beyond it).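

In this assay, a carboxy-bearing group is now seen on the amide-type nitrogen: 1-carboxy-2-methylpropyl, replacing a group with the same heavy-atom count, gives a 1.5-fold higher number from compound 3 to compound 4 (0.18 log units; within the scatter). Replacing 1-(hydroxymethyl)-1-methylethyl with it gives a 2.2-fold higher number from compound 2 to compound 4 (0.33 log units; beyond the scatter), and replacing 1-(hydroxymethyl)ethyl with it gives a 4.2-fold higher number from compound 1 to compound 4 (0.63 log units; beyond the scatter), so the change on this nitrogen reaches beyond the scatter against these two hydroxymethyl groups. Nothing available explains these differences. From the compounds shown here alone, how an amine or a methyl ester on this nitrogen would compare remains open, as does the effect of the opposite configuration at the stereocentre of 1-carboxy-2-methylpropyl.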